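A few compounds are considered here, and "the series" means these few. Any claim that something is new, unique, unknown or untested is made for them only; others in the source may bear on it.

Measured so far in an ADME assay on a cell-free system (plasma, Homo sapiens) for metabolic stability, with Plasma (Rattus norvegicus) as the target, read by HPLC, at pH 7.4; on this read-out higher numbers stand for a longer-lived compound and lower numbers for a shorter-lived compound:
- compound 1, `CC(=O)Oc1ccccc1C(=O)O[C@H]1CO[C@H]2[C@@H]1OC[C@H]2OC(=O)c1ccccc1C`: 0.035 h
- compound 2, `CC(=O)Oc1ccccc1C(=O)O[C@H]1CO[C@H]2[C@@H]1OC[C@H]2OC(=O)c1ccccc1OC(=O)c1ccccc1`: 0.385 h
- compound 3, `CC(=O)Oc1ccccc1C(=O)O[C@H]1CO[C@H]2[C@@H]1OC[C@H]2O[N+](=O)[O-]`: 0.0144 h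

Compound 1 sits second highest of the three numbers. Its nearest neighbour is compound 3, reached by a 2.4-fold lower number from compound 1 to compound 3 (0.39 log units; beyond the scatter); its furthest is compound 2, reached by an 11-fold higher number from compound 1 to compound 2 (1.04 log units; beyond the scatter).

Compound 4, `CC(=O)Oc1ccccc1C(=O)O[C@H]1CO[C@H]2[C@@H]1OC[C@H]2OC(=O)c1cccc(CO[N+](=O)[O-])c1`, is not yet measured in this assay. It differs from compound 1 in one place: 3-((nitrooxy)methyl)phenyl in place of 2-methylphenyl on a carbonyl carbon

Neither measured step reproduces this change. The step from compound 1 to compound 2 alters the same aryl ring, adding a substituent on an aromatic carbon, and gave a large rise; the step from compound 1 to compound 3 removes the whole (2-methylphenyl)carbonyl and gave a modest fall. Compound 4 keeps the aryl ester and adds a substituent to its ring, so the first step is the closer analogy, but the added group is different and smaller than benzoyloxy, so only part of that rise is expected, with wide uncertainty.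

Compound 4 is therefore expected to give 0.06 h in this assay, plausibly between 0.02 h and 0.2 h, a step of a 1.7-fold higher number from compound 1 to compound 4 (0.23 log units; within the scatter) that is expected to be upward but could fall within the scatter.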

Compound 4, half-life: 0.0433 h
Estimate against measurement, compound 4: 1.4-fold (0.14 log units) above; the range from low to high includes it.
By their numbers in this assay, from the lowest: compound 3; then compounds 1 and 4 (each within the scatter of the next); then compound 2.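

At the aryl group on a carbonyl carbon, in this assay, 3-((nitrooxy)methyl)phenyl in place of 2-methylphenyl gives a 1.2-fold higher number from compound 1 to compound 4 (0.09 log units; within the scatter), so this exchange leaves compound 4 indistinguishable from compound 1 even though the entering group carries hydrogen-bond acceptors and the leaving group has none. The one other change on this aryl ring gives an 11-fold higher number from compound 1 to compound 2 (1.04 log units; beyond the scatter), so the compounds shown establish that a change here can produce a large step but need not produce one, and the outcome depends on the group that enters. Nothing available on these compounds bears on why the two changes on this ring differ so much.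

From the compounds shown here alone, it remains open whether the size of the step follows the group itself or the place it occupies on the ring, as the two changes differ in both. A ring carrying an amine or a carboxylic acid, or a longer chain ending in the same nitrooxy group, would show whether compound 4 or compound 2 is the more typical case for this position.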